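A few compounds are considered here, and "the series" means these few. Any claim that something is new, unique, unknown or untested is made for them only; others in the source may bear on it.

In an ADME assay on HEK-293T cells (Homo sapiens) for cytotoxicity, read by MTT assay, with a stated time of 24 h (a lower number here means that less compound is tolerated, a higher number that more compound is tolerated), compound 3 (`O=S(=O)(c1ccccc1)n1c(-c2cn(-c3ccccc3)nc2-c2ccc(C(F)(F)F)cc2)nc2ccccc21`) gives 128000 nM, within the scatter of compound 1 (`FC(F)(F)c1ccc(-c2nn(-c3ccccc3)cc2-c2nc3ccccc3[nH]2)cc1`) at 167000 nM, while compound 2 (`COc1ccc(S(=O)(=O)n2c(-c3cn(-c4ccccc4)nc3-c3ccc(F)cc3)nc3ccccc32)cc1`) gives a clearly lower 37300 nM. Compound 4 (`COc1ccc(S(=O)(=O)n2c(-c3cn(-c4ccccc4)nc3-c3ccc(C(F)(F)F)cc3)nc3ccccc32)cc1`) changes compound 3 in one place: methoxy in place of hydrogen on an aromatic carbon, so phenylsulfonyl becomes (4-methoxyphenyl)sulfonyl. For the measured compounds named here, the only measured single-change step, a 1.3-fold lower number from compound 1 to compound 3 (0.12 log units; within the scatter), adds phenylsulfonyl and does not test methoxy. Compound 2, at 37300 nM, carries the same (4-methoxyphenyl)sulfonyl but also differs from compound 3 elsewhere, so it offers only a hint. In this assay, the expected change is modest and downward, a 1.7-fold lower number from compound 3 to compound 4 (0.23 log units; within the scatter). The estimate for compound 4 is 75000 nM, with an expected range of 32000 nM to 150000 nM.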

Compound 4, half-maximal cytotoxic concentration: > 300000 nM
Compound 4: no number, only a limit; the forecaster's own chance of this, stated with the estimate: 3%; at least 4.0-fold (0.60 log units) between middle value and limit.
By their numbers in this assay, from the lowest: compound 2; then compounds 3 and 1 (each within the scatter of the next). At a limit, above all of these: compound 4.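

In this assay compound 4 gives > 300000 nM, which is a limit and not a number. On this aromatic carbon, para to a large group, methoxy in place of hydrogen raises the tolerated concentration, an at least 2.3-fold higher number from compound 3 to compound 4 (0.36 log units; beyond the scatter). With (4-methoxyphenyl)sulfonyl kept, trifluoromethyl in place of fluoro also counts, an at least 8.0-fold higher number from compound 2 to compound 4 (0.90 log units; beyond the scatter), while the step for adding the whole sulfonyl group, an at least 1.7-fold higher number from compound 1 to compound 4 (0.25 log units; that floor lies within the scatter), stays unresolved.

Going by these compounds, how far the true value of compound 4 lies beyond the limit remains open. So does whether an amine, a carboxylic acid or a longer chain such as ethoxy at this position would shift the number in the same direction.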